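A few compounds are considered here, and "the series" means these few. Any claim that something is new, unique, unknown or untested is made for them only; others in the source may bear on it.

Compound 1 `CNC(=O)c1cc(C(=O)NC2CC2)cc2c1OC[C@H]2c1cccc(OC)c1`: >= 161 ug/mL
Compound 2 `CNC(=O)c1cc(C(=O)N[C@H]2[C@@H]3C[C@H](O)C[C@@H]32)cc2c1OC[C@@]2(C)c1ccccc1`: >= 151 ug/mL
Compound 3 `CNC(=O)c1cc(C(=O)N[C@H]2[C@@H]3COC[C@@H]32)cc2c1OC[C@H]2c1ccncc1`: >= 184 ug/mL

All three entries come from a physicochemical assay for solubility (a higher number here means a more soluble compound, a lower number a less soluble compound), and each one is a limit of the assay rather than a number. For compound 2 the reading is the limit of >= 151 ug/mL in this assay, at which 1 of the 3 values shown sits. Since none of the three is an exact number, the compounds cannot be put in order, and compound 2 has no clear place among them. Among the measured compounds shown here, no two measured compounds differ in only one place, so no measured step is available as a guide.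

Compound 4 `CNC(=O)c1cc(C(=O)N[C@H]2[C@@H]3COC[C@@H]32)cc2c1OC[C@@]2(C)c1ccccc1` differs from compound 2 in one place, on an amide-type nitrogen: a group of 6 heavy atoms (5 carbon, 1 oxygen; one three-membered non-aromatic ring of carbon only, one five-membered non-aromatic ring with 1 hetero atom) in place of a group of 7 heavy atoms (6 carbon, 1 oxygen; one three-membered non-aromatic ring of carbon only, one five-membered non-aromatic ring of carbon only), on an amide-type nitrogen.

With only limits to go on, no step beyond the usual scatter is expected in this assay, in either direction. Compound 3 also stands at a limit, of >= 184 ug/mL. Compound 1 does the same, with its limit of >= 161 ug/mL. Compound 4 is therefore expected to read close to these limits, and it may well be reported as a limit too. The estimated change, a step that the limit leaves unreadable from compound 2 to compound 4, is expected to stay within the scatter. For compound 4 the estimate is 170 ug/mL, with an expected range of 110 ug/mL to 205 ug/mL.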

Compound 4, solubility: >= 147 ug/mL
Compound 4: no number, only a limit; the forecaster's own chance of this, stated with the estimate: 75%; the middle value is on the limit's open side.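

In this assay compound 4 gives >= 147 ug/mL, which is a limit and not a number. Compound 2 also gives a limit, >= 151 ug/mL, so no step can be read between compound 2 and compound 4. The compounds shown leave open how far each true solubility lies past its limit, and whether swapping the group on the amide-type nitrogen changes it at all.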